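Dichlorophenyl Replaces Methylphenyl on the Ring Nitrogen

The source may hold more compounds than are shown below. What is called first, only, known or untested is meant among the compounds shown, and "the series" means these compounds.

Among the measured compounds shown here, compound 1 `CO[C@@H]1CC=C2NN(c3ccc(C)cc3)C(=O)CC[C@]2(c2ccccc2)O1` gives 1700 nM in a functional assay on SK-N-SH cells (Homo sapiens) for cytotoxicity, read by sulforhodamine B assay, with a stated time of 48 h (on this read-out higher numbers stand for weaker inhibition and lower numbers for stronger inhibition), the lowest of the three numbers measured so far. Compound 2 `CO[C@@H]1CC=C2NN(c3ccc([N+](=O)[O-])cc3)C(=O)CC[C@]2(c2ccccc2)O1` gives 7300 nM, and compound 3 `COc1ccc(N2NC3=CC[C@@H](OC)O[C@@]3(c3ccccc3)CCC2=O)cc1` gives 4600 nM. The two steps that alter the aryl group on the ring nitrogen, a 4.3-fold higher number from compound 1 to compound 2 (0.63 log units; beyond the scatter) and a 2.7-fold higher number from compound 1 to compound 3 (0.43 log units; beyond the scatter), both raised the number modestly, while a 1.6-fold lower number from compound 2 to compound 3 (0.20 log units; within the scatter) stays within the scatter. Compound 4 `CO[C@@H]1CC=C2NN(c3cc(Cl)cc(Cl)c3)C(=O)CC[C@]2(c2ccccc2)O1` differs from compound 1 by 3,5-dichlorophenyl in place of 4-methylphenyl on an amide-type nitrogen in a ring. Those two steps bear on this change, and a modestly higher number in this assay is therefore expected, a 2.1-fold higher number from compound 1 to compound 4 (0.31 log units; beyond the scatter). Compound 4 is estimated at 3500 nM, with a range of 1200 nM to 10000 nM.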

Compound 4, half-maximal inhibitory concentration: 7110 nM
Compound 4: middle estimate off by 2.0-fold (0.31 log units), on the low side; the measured number falls inside the stated range.
By their numbers in this assay, from the lowest: compound 1; then compounds 3, 4 and 2 (each within the scatter of the next).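

In this assay the 3,5-dichlorophenyl group joins the other replacements of 4-methylphenyl on the amide-type nitrogen, with a 4.2-fold higher number from compound 1 to compound 4 (0.62 log units; beyond the scatter) leaving compound 1 the lowest of all four. The replacements do not separate from one another, even with the first chlorine-bearing aryl group: a 1.5-fold higher number from compound 3 to compound 4 (0.19 log units; within the scatter) and a 1.0-fold lower number from compound 2 to compound 4 (0.01 log units; within the scatter) both stay within the scatter. No measurement shown accounts for this result.

The compounds shown leave open whether phenyl, 4-chlorophenyl or 4-aminophenyl on this nitrogen would match compound 1 or give a lower number.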